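This account rests on a few compounds, and the source may have more. Where it says the series, first, only, none or still open, it means among the compounds named here.

Series notes, carbamate and sulfonamide variants on the piperidine nitrogen of the shared core.

Within the data shown here, compound 2 `CC(C)(C)OC(=O)N1CCC(Oc2ncnc3c2CCN3c2ccc(S(C)(=O)=O)cc2F)CC1` gives 139% in a functional assay on CHO-K1 cells with Glucose-dependent insulinotropic receptor (Homo sapiens) as the target, read by a luciferase reporter, with a stated time of 5 h (on this read-out higher numbers stand for larger maximal responses and lower numbers for smaller maximal responses), the highest of the three numbers measured so far. Compound 1 `CC(C)OC(=O)N1CCC(Oc2ncnc3c2CCN3c2ccc(C#N)cc2F)CC1` sits nearest with 134%, a gap that lies within the scatter, so no order between compound 1 and compound 2 is claimed. Compound 3 `COC(=O)N1CCC(Oc2ncnc3c2CCN3c2ccc(S(C)(=O)=O)cc2F)CC1` is furthest with 119%, and the step of a number 20 percentage points lower from compound 2 to compound 3 (beyond the scatter) came with methyl in place of tert-butyl on an oxygen next to a carbonyl group.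

Compound 4 `CCS(=O)(=O)N1CCC(Oc2ncnc3c2CCN3c2ccc(S(C)(=O)=O)cc2F)CC1` differs from compound 2 by ethylsulfonyl in place of tert-butoxycarbonyl on an amine nitrogen in a ring. Among the measured compounds shown here, the only measured step that touches the same part of the molecule is the one from compound 2 to compound 3, which trimmed the group on the carbamate oxygen and lowered the largest response by a modest amount beyond the scatter. Whether an ethylsulfonyl group behaves like a smaller carbamate is not settled by anything measured here; the step from compound 2 to compound 3 is the sole point of reference, and it points to a lower number. In this assay, a decrease of similar size is therefore expected for compound 4, a number 21 percentage points lower from compound 2 to compound 4 (beyond the scatter). The value expected for compound 4 is 118%, with a range from 95% to 140%.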

Compound 4, largest response reached (reported as percent of maximum), in percent of the reference or control that the assay uses: 51%
The estimate for compound 4 lay 67 percentage points above the measured number; the measured number lies below the stated range.
By their numbers in this assay, from the lowest: compound 4; then compound 3; then compounds 1 and 2 (each within the scatter of the next).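

On the amine nitrogen in the six-membered non-aromatic ring, replacing the carbamate outweighs any change made within it in this assay: ethylsulfonyl in place of tert-butoxycarbonyl gives a number 88 percentage points lower from compound 2 to compound 4 (beyond the scatter) and ethylsulfonyl in place of methoxycarbonyl gives a number 68 percentage points lower from compound 3 to compound 4 (beyond the scatter) whereas methyl in place of tert-butyl on the carbamate oxygen gave only a number 20 percentage points lower from compound 2 to compound 3 (beyond the scatter) as the earlier reference. The large fall holds from both carbamates, so at this position the move to ethylsulfonyl is not simply a further step along the trimming seen from the tert-butyl carbamate to the methyl carbamate. Nothing available bears on the reason for this fall in maximal response.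

The compounds shown leave open whether the loss follows the sulfonyl link itself or the ethyl on it, a question that a methylsulfonyl or phenylsulfonyl group on the same nitrogen, or an acetyl amide there, would help to separate. Also open, going by these compounds, is whether the same fall would appear with the nitrile of compound 1 on the shared core in place of the methylsulfonyl group.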